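Resorcinol Lipid Acetates: Cytotoxicity on Vero Cells

This account rests on a few compounds, and the source may have more. Where it says the series, first, only, none or still open, it means among the compounds named here.

Measured compounds:
- compound 1, `CC/C=C\C/C=C\C/C=C\CCCCCCCc1cc(O)cc(O)c1`: 104000 nM
- compound 2, `CCCCC/C=C\C/C=C\CCCCCCCc1cc(OC(C)=O)cc(OC(C)=O)c1`: 124000 nM
- compound 3, `CC/C=C\C/C=C\C/C=C\CCCCCCCc1cc(OC(C)=O)cc(OC(C)=O)c1`: 138000 nM

In an ADME assay on Vero cells (Homo sapiens) for cytotoxicity against Vero (Chlorocebus sabaeus), read by MTT assay (a lower number here means a stronger inhibitor, a higher number a weaker inhibitor), compound 3 gives the highest of the three numbers, but its neighbours sit close: compound 2 is a little lower, and compound 1 a little lower still, and both gaps are within the scatter. The three compounds share the same core and differ only in their long chain or in the groups on the two ring oxygens.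

Compound 4, `CC/C=C\C[C@H](CC/C=C\CCCCCCCc1cc(OC(C)=O)cc(OC(C)=O)c1)OC(C)=O`, is not yet measured. It differs from compound 3 in this way: a group of 11 heavy atoms (9 carbon, 2 oxygen; no ring) in place of a group of 7 heavy atoms (7 carbon; no ring), on a saturated chain carbon bound to a double-bonded chain carbon

Among the compounds with values here, the only measured step that touches the same place is a 1.1-fold higher number from compound 2 to compound 3 (0.05 log units; within the scatter), which swapped one chain piece for another at a saturated chain carbon bound to a double-bonded chain carbon and moved the number hardly at all. Within the data shown here, the change to compound 4 is larger than that swap, adding two oxygens and a stereocentre on the chain, so the single earlier step is a loose guide. With no sign that chain edits matter here, no step beyond the scatter is expected, a 1.1-fold lower number from compound 3 to compound 4 (0.03 log units; within the scatter).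

Compound 4 is therefore estimated at 130000 nM in this assay, with a range from 65000 nM to 260000 nM.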

Compound 4, half-maximal inhibitory concentration: 82000 nM
The estimate for compound 4 lay 1.6-fold (0.20 log units) above the measured number; the range from low to high includes it.
By their numbers in this assay, from the lowest: compounds 4, 1, 2 and 3 (each within the scatter of the next).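

In this assay, the entering group of 11 heavy atoms, with its 2 hydrogen-bond acceptors and 1 defined stereocentre, replaces the hepta-1,4-dien-1-yl group and gives a 1.7-fold lower number from compound 3 to compound 4 (0.23 log units; within the scatter); the comparison with the other acetylated compound gives a 1.5-fold lower number from compound 2 to compound 4 (0.18 log units; within the scatter). The earlier chain swap at this place, on a saturated chain carbon bound to a double-bonded chain carbon, was a small edit that added no oxygen, so it could not show whether a larger, oxygen-bearing group would shift the number, and here even that much bigger change stays within the scatter. No measurement at hand bears on how this group acts on the cells, so the result stays a plain observation.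

Still open, as far as these compounds go, is whether the other arrangement at the stereocentre, or a free hydroxyl, an amine or a carboxylic acid on the chain at this place, would produce a step beyond the scatter. A longer chain is also untested among these compounds, so how far this place stays undemanding remains unknown.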